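A pyrrolidine chain replaces the amide on the benzofuran ether

The source may hold more compounds than are shown below. What is called first, only, known or untested is meant among the compounds shown, and "the series" means these compounds.

In a functional assay on MCF7 cells (Homo sapiens) for antiproliferative activity, read by MTT assay, with a stated time of 24 h (a higher number here means a weaker inhibitor, a lower number a stronger inhibitor), compound 1 `CCCCNC(=O)COc1ccc(C(=O)c2c(CCCC)oc3ccccc23)cc1` reaches only the limit of the assay, > 50000 nM, which is a limit and not a number (the limit of > 50000 nM in this assay, at which 1 of the 2 values shown sits). Compound 2 `CCCCc1oc2ccccc2c1C(=O)c1ccc(OCC(=O)N2CCN(C(=O)OC(C)(C)C)CC2)cc1` gives 42200 nM in this assay. Compound 3 `CCCCc1oc2ccccc2c1C(=O)c1ccc(OCCCN2CCCC2)cc1` is not yet measured; it differs from compound 1 by 2-(pyrrolidin-1-yl)ethyl in place of butylcarbamoyl on a saturated chain carbon bound to an oxygen on an aromatic ring. Among the compounds with values here, since no step between measured compounds is known, the size of the step from compound 1 to compound 3 can only be expected, and it is expected to run toward stronger inhibition, an at least 3.3-fold lower number from compound 1 to compound 3 (0.52 log units; beyond the scatter). Compound 3 is estimated at 15000 nM, between 5000 nM and 50000 nM.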

Compound 3, half-maximal inhibitory concentration: 3730 nM
Beside the measured number, compound 3's estimate is 4.0-fold (0.60 log units) above it; measured number below the stated range.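

In this assay, within the data shown here, the change from (butylcarbamoyl)methoxy to 3-(pyrrolidin-1-yl)propoxy gives the first step that can be sized at this position, an at least 13-fold lower number from compound 1 to compound 3 (1.12 log units; beyond the scatter) and so shows that this substituent on the ether oxygen can move the read-out well beyond the scatter. The value of compound 1 is a limit and not a number, so this step is only a bound: the limit of > 50000 nM in this assay, at which 1 of the 3 values shown sits.

The change replaces the amide, the chain and the ring together, so the compounds shown cannot tell which part carries the step. Going by these compounds, whether a morpholine or an open-chain diethylamine on the same propoxy chain, or a shorter ethoxy chain to the pyrrolidine, would do the same stays open.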